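Trifluoromethyl in place of methoxy: notes on compound 3

This account rests on a few compounds, and the source may have more. Where it says the series, first, only, none or still open, it means among the compounds named here.

In a functional assay on A549/CDDP cells (Homo sapiens) for antiproliferative activity, read by MTT assay, with a stated time of 72 h (on this read-out higher numbers stand for weaker inhibition and lower numbers for stronger inhibition), compound 1 `COc1ccc(/C=C/C(=O)/C=C/c2nc(C)c(C)nc2C)cc1` gives 3610 nM and compound 2 `COc1ccc(/C=C/C(=O)/C=C/c2nc(C)c(C)nc2C)cc1OC` gives 2440 nM with these two values, the only ones so far, within the scatter of each other. Next in line is compound 3 `Cc1nc(C)c(/C=C/C(=O)/C=C/c2ccc(C(F)(F)F)cc2)nc1C` with trifluoromethyl in place of methoxy on an aromatic carbon, para to a large group, as counted here: trifluoromethyl in place of methoxy on an aromatic carbon on the core of compound 1. For the measured compounds named here, the one measured step is a 1.5-fold lower number from compound 1 to compound 2 (0.17 log units; within the scatter) for methoxy in place of hydrogen on an aromatic carbon. That step removes no methoxy and brings in no trifluoromethyl, so it bears only loosely on this change. No step beyond the scatter is therefore expected in this assay and no firm direction is claimed. The expected step is a 1.2-fold lower number from compound 1 to compound 3 (0.08 log units; within the scatter) as a working estimate. Compound 3 is estimated at 3000 nM with an expected range from 1000 nM to 9000 nM until it is measured.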

Compound 3, half-maximal inhibitory concentration: 6900 nM
Estimate against measurement, compound 3: 2.3-fold (0.36 log units) below, within the range that was stated.
By their numbers in this assay, from the lowest: compounds 2, 1 and 3 (each within the scatter of the next, the first and the last beyond it).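

Unlike the earlier step, which left this methoxy in place, this change removes it, and in this assay it reads as a 1.9-fold higher number from compound 1 to compound 3 (0.28 log units; within the scatter) on the aromatic carbon para to a large group. Methoxy at this place is therefore not needed to keep the number within the scatter of compound 1, even though the trifluoromethyl that enters counts no hydrogen-bond acceptor and the methoxy that leaves counts one. No measurement at hand offers an explanation for this result or separates the two groups by any property. Going by these compounds, whether an amine, a carboxylic acid or a longer chain at this place would also stay within the scatter remains open. Also open, on these data alone, is whether the same swap would read alike on the core of compound 2.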